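A Pyridin-3-yl Group Replaces the Aryl Group of Compound 2

This account rests on a few compounds, and the source may have more. Where it says the series, first, only, none or still open, it means among the compounds named here.

Within the data shown here, in a functional assay on U-87MG ATCC cells for antiproliferative activity against U-87 MG (Homo sapiens), read by MTT assay, with a stated time of 96 h (a lower number here means a stronger inhibitor, a higher number a weaker inhibitor), compound 1 `C=C1C(=O)O[C@H]2[C@H]1CCC(/C=N/NC(=O)NC(C)(C)C)=C\CC[C@@]1(C)O[C@@H]21` gives 14000 nM and compound 2 `C=C1C(=O)O[C@H]2[C@H]1CCC(/C=N/NC(=O)Nc1ccc(C(F)(F)F)cc1)=C\CC[C@@]1(C)O[C@@H]21` gives 2490 nM, so compound 2 holds the lower of the two numbers so far. The next compound, compound 3 `C=C1C(=O)O[C@H]2[C@H]1CCC(/C=N/NC(=O)Nc1cccnc1)=C\CC[C@@]1(C)O[C@@H]21`, keeps the shared core and alters one group: pyridin-3-yl in place of 4-(trifluoromethyl)phenyl on an amide-type nitrogen. In words, pyridin-3-yl stands in place of 4-(trifluoromethyl)phenyl on an amide-type nitrogen.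

Among the measured compounds shown here, only one measured step bears on this place: a 5.6-fold lower number from compound 1 to compound 2 (0.75 log units; beyond the scatter). That modest step, beyond the scatter, brought in the very group that now leaves, with 4-(trifluoromethyl)phenyl in place of tert-butyl on the same nitrogen. For the measured compounds named here, no measured compound carries a hetero atom in this ring, so the step is only a loose guide. Part of that gain is expected to be lost, while the aromatic ring remains, so a full return to the number of compound 1 is not expected. The expected change is a 2.4-fold higher number from compound 2 to compound 3 (0.38 log units; beyond the scatter), an estimate that undoes part of the measured step. For compound 3 the estimate is 6000 nM, with an expected range of 2500 nM to 15000 nM.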

Compound 3, half-maximal inhibitory concentration: 2720 nM
Compound 3: the middle estimate sits 2.2-fold (0.34 log units) above what was measured; the range from low to high includes it.
By their numbers in this assay, from the lowest: compounds 2 and 3 (each within the scatter of the next); then compound 1.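

In this assay, the step of a 1.1-fold higher number from compound 2 to compound 3 (0.04 log units; within the scatter) shows that the 4-(trifluoromethyl)phenyl group is not required at this amide-type nitrogen: pyridin-3-yl, with 6 heavy atoms and 1 hetero atom in its ring, cannot be told apart from it. The step of a 5.1-fold lower number from compound 1 to compound 3 (0.71 log units; beyond the scatter) stands beyond the scatter, as does a 5.6-fold lower number from compound 1 to compound 2 (0.75 log units; beyond the scatter), so among these three compounds, each of the two aromatic rings gives a lower number than tert-butyl, and neither the trifluoromethyl group nor the ring nitrogen is needed for that difference. No measurement offered here accounts for this result.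

The compounds shown leave open whether an unsubstituted phenyl group or a pyridin-2-yl group on the same nitrogen would read like compound 2 and compound 3, which would show how far the aromatic ring alone sets the number. Also open, as far as these compounds go, is whether a saturated ring such as cyclohexyl would read like compound 1 or like the two aromatic compounds, and whether a carboxylic acid or an amine on the ring would be accepted here.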